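Urea in Place of Amide at the Anilide Carbonyl

The source may report more compounds than this note shows. Statements on the series, on what has been measured and on what is new or still open speak of the compounds shown alone.

Compound 1 `COc1cc(-c2nn(-c3cccc(NC(=O)c4cccc(C(F)(F)F)c4)c3)cc2-c2ccncc2)ccc1Cl` carries a 3-(trifluoromethyl)phenyl group on the carbonyl carbon of its anilide. In a functional assay on COLO 205 cells (Homo sapiens) for inhibition, read by sulforhodamine B assay, with a stated time of 48 h (a higher number here means that more compound is tolerated, a lower number that less compound is tolerated), compound 1 gives 24800 nM, the highest of the two numbers recorded so far. Among the compounds with values here, the only comparison is compound 2 `O=C(Nc1cccc(-n2cc(-c3ccncc3)c(-c3ccc(Cl)c(O)c3)n2)c1)Nc1ccc(Cl)c(C(F)(F)F)c1`, which differs in more than one place and in this assay gives 16100 nM; the two values sit within the scatter of each other, so nothing about order can be read from them.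

Compound 3 `COc1cc(-c2nn(-c3cccc(NC(=O)Nc4ccc(Cl)c(Cl)c4)c3)cc2-c2ccncc2)ccc1Cl` is obtained from compound 1 by the change ((3,4-dichlorophenyl)amino in place of 3-(trifluoromethyl)phenyl on a carbonyl carbon). Within the data shown here, no step between two measured compounds isolates this change, so the expectation rests on compound 2 and on compound 1 itself. The step is expected to be small, at most a modest move toward a lower number, a 1.7-fold lower number from compound 1 to compound 3 (0.22 log units; within the scatter). Compound 3 is therefore expected to give about 15000 nM in this assay, within 6000 nM to 40000 nM.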

Compound 3, concentration lethal to 50% of the cells: 3140 nM
Estimate against measurement, compound 3: 4.8-fold (0.68 log units) above; the measured number lies below the stated range.
By their numbers in this assay, from the lowest: compound 3; then compounds 2 and 1 (each within the scatter of the next).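

In this assay, within the data shown here, the change to (3,4-dichlorophenyl)amino on this carbonyl carbon gives a 7.9-fold lower number from compound 1 to compound 3 (0.90 log units; beyond the scatter) and lies beyond the scatter, the first step that can be read at all. What sits on a carbonyl carbon whose other neighbour is an amide-type nitrogen therefore matters to this number, and the urea of compound 3 does not read like the anilide of compound 1. The step brings in a nitrogen with one hydrogen-bond donor and replaces trifluoromethyl with two chlorines at once, and nothing measured here explains it.

The compounds shown leave open which of these two differences carries the step. A urea bearing a 3-(trifluoromethyl)phenyl group and an amide bearing a 3,4-dichlorophenyl group on the carbonyl carbon would pull them apart.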